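Carrying the Sulfonyl Aryl Swap onto a Chloro Core

The source may report more compounds than this note shows. Statements on the series, on what has been measured and on what is new or still open speak of the compounds shown alone.

Three compounds that share a core were measured in an assay on isolated protein for displacement of a labelled ligand from metabotropic glutamate receptor 5 (Homo sapiens), with a stated time of 60 min, tested at 1 uM; a higher number here means more inhibition at the concentration tested (going by the name of the read-out), a lower number less inhibition. Compound 1 `Cc1cc(C)cc(S(=O)(=O)c2cnc3ccc(C)cc3c2N2CCC(C)CC2)c1` gives 80%. Compound 2 `Cc1ccc2ncc(S(=O)(=O)c3ccc(C#N)cc3)c(N3CCC(C)CC3)c2c1` gives 55%, and compound 3 `CC1CCN(c2c(S(=O)(=O)c3ccc(C#N)cc3)cnc3ccc(Cl)cc23)CC1` gives 31%, the lowest of the three, with compound 2 a step above it and compound 1 further above.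

Compounds 2 and 1 differ in one place: 3,5-dimethylphenyl in place of 4-cyanophenyl on a sulfonyl sulfur This change gave the step of a number 25 percentage points higher from compound 2 to compound 1 (beyond the scatter). Compounds 2 and 3 differ in their cores: chloro in place of methyl on an aromatic carbon That difference gave the step of a number 24 percentage points lower from compound 2 to compound 3 (beyond the scatter).

Compound 4 `Cc1cc(C)cc(S(=O)(=O)c2cnc3ccc(Cl)cc3c2N2CCC(C)CC2)c1` has not yet been measured. For the measured compounds named here, it stands to compound 3 as compound 1 stands to compound 2: 3,5-dimethylphenyl in place of 4-cyanophenyl on a sulfonyl sulfur The place of the change is the same, word for word, in both pairs, so it is the same change, this time made on the core of compound 3 rather than on the core of compound 2; among the four compounds it occurs twice, but only one instance has been measured, so how well it carries from one core to the other is not yet known.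

Resting on that single instance, compound 4 is expected to show a number 25 percentage points higher from compound 3 to compound 4 (beyond the scatter), because the same change on the other core gave a number 25 percentage points higher from compound 2 to compound 1 (beyond the scatter). Compound 4 is therefore estimated at 56% in this assay. The likely span for compound 4 runs from 40% to 70%.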

Compound 4, a percentage reported as inhibition, at one concentration (the size of the read-out at that concentration, not a potency): 49%
Estimate against measurement, compound 4: 7 percentage points above; the range from low to high includes it.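

In this assay the change to 3,5-dimethylphenyl in place of 4-cyanophenyl carried over to the core of compound 3, giving a number 18 percentage points higher from compound 3 to compound 4 (beyond the scatter), and the two instances of the change agree: the same change on two cores in this assay, a number 25 percentage points higher (beyond the scatter) from compound 2 to compound 1 and a number 18 percentage points higher (beyond the scatter) from compound 3 to compound 4, 7 percentage points apart, within the scatter of two such steps. Seen from the other side, chloro in place of methyl moved the number the same way with either group on the sulfonyl sulfur, giving a number 31 percentage points lower from compound 1 to compound 4 (beyond the scatter), and these two instances agree as well: the same change on two cores in this assay, a number 24 percentage points lower (beyond the scatter) from compound 2 to compound 3 and a number 31 percentage points lower (beyond the scatter) from compound 1 to compound 4, 7 percentage points apart, within the scatter of two such steps. This shows that the two changes behaved consistently across these four compounds, but two instances of each cannot show that either would carry to a further core, and they do not explain why either change moves the number.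

The compounds shown leave open whether other groups on the sulfonyl sulfur, such as an unsubstituted phenyl or a pyridine, would follow the same pattern, and how a fluoro or a methoxy group would compare with chloro and methyl on the aromatic carbon. On these data alone, each compound is also reported at a single concentration, so their potencies remain open.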